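Extending compound 2 on the fused bicyclic ring

A few compounds are considered here, and "the series" means these few. Any claim that something is new, unique, unknown or untested is made for them only; others in the source may bear on it.

Three compounds have been characterised in a physicochemical assay for lipophilicity, at pH 7.4; on this read-out lower numbers stand for lower lipophilicity and higher numbers for higher lipophilicity. Compound 1 `CN(Cc1ccc2nccn2c1)c1nnc(-c2ccccc2)o1` gives 2.4. Compound 2 `Cc1cc(-c2c(C)nn(C)c2C)cnc1-c1nnc(N(C)Cc2ccc3nccn3c2)o1` gives 2.8, which places it second highest of the three, above compound 1 by more than the scatter and below compound 3 by more than the scatter. Compound 3 `Cc1cc(-c2c(C)nn(C)c2C)ccc1-c1nnc(N(C)Cc2ccc3ncc(-c4cnn(CCN(C)C)c4)n3c2)o1` gives 3.5.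

Compound 4 `Cc1cc(-c2c(C)nn(C)c2C)cnc1-c1nnc(N(C)Cc2ccc3ncc(-c4ccc(CN(C)C)nc4)n3c2)o1` has not yet been measured in this assay. It is built from compound 2 by one change: 6-((dimethylamino)methyl)pyridin-3-yl in place of hydrogen on an aromatic carbon. Within the data shown here, no measured pair in this set differs by exactly this change, so the step must be expected rather than read off. Compound 3 carries a larger substituent at the same kind of position together with a second alteration, and its value stands above that of compound 2, which points upward. For compound 4 the step from compound 2 is expected to be a number 0.40 log units higher from compound 2 to compound 4 (beyond the scatter), a modest rise beyond the scatter. Compound 4 is therefore estimated at 3.2, with a plausible range from 2.6 to 3.8.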

Compound 4, distribution coefficient: 2.5
Compound 4: the middle estimate sits 0.70 log units above what was measured, and the stated range ends above it.
By their numbers in this assay, from the lowest: compounds 1, 4 and 2 (each within the scatter of the next, the first and the last beyond it); then compound 3.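

In this assay the exchange of hydrogen for 6-((dimethylamino)methyl)pyridin-3-yl gives a number 0.30 log units lower from compound 2 to compound 4 (within the scatter) and so shows that this aromatic carbon of the five-membered ring can carry a group of 10 heavy atoms without a step beyond the scatter. Among these compounds, this is the first single-place reading at this position, since compound 3 differs from compound 2 in more than one place and its value cannot be assigned to this carbon alone. Nothing measured here accounts for the size of this step.

Going by these compounds, it remains open whether the pyridine ring and the dimethylaminomethyl group each leave this read-out unmoved or offset one another. An unsubstituted pyridin-3-yl or a phenyl on the same carbon would separate the two contributions, and a longer amine chain on the pyridine would test how far the result extends.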